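Replacing pyridin-3-yl with 4-(hydroxymethyl)-1,3-thiazol-2-yl on the amide

The source may report more compounds than this note shows. Statements on the series, on what has been measured and on what is new or still open speak of the compounds shown alone.

Compound 1 `CN(C)Cc1csc(NC(=O)c2cc(C(C)(C)C)nn2Cc2ccccc2)n1` and compound 2 `CC(C)(C)c1cc(C(=O)Nc2cccnc2)n(Cc2ccccc2)n1` share a core and differ on an amide-type nitrogen. In a physicochemical assay for solubility, read by nephelometry, measured as kinetic solubility, at pH 2.0 (on this read-out lower numbers stand for lower solubility and higher numbers for higher solubility), compound 1 gives > 100 ug/mL, which is a limit of the assay. In this assay compound 2 gives > 100 ug/mL, likewise a limit and not a number. Compound 2 therefore has no exact standing in the series. The two values share one limit: the limit of > 100 ug/mL in this assay, at which 2 of the 2 values shown sit. For the measured compounds named here, the only measured step is a step that the two limits leave unreadable from compound 1 to compound 2, so it offers no size to carry forward.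

Compound 3 `CC(C)(C)c1cc(C(=O)Nc2nc(CO)cs2)n(Cc2ccccc2)n1` has 4-(hydroxymethyl)-1,3-thiazol-2-yl in place of the pyridin-3-yl of compound 2 on an amide-type nitrogen: 4-(hydroxymethyl)-1,3-thiazol-2-yl in place of pyridin-3-yl on an amide-type nitrogen. Going by the values given here, no measured step covers this exchange. The expectation therefore starts from compound 2 at > 100 ug/mL and allows a modest fall in this assay or a repeat of the limit. The estimated step is an at least 1.2-fold lower number from compound 2 to compound 3 (0.09 log units; that floor lies within the scatter). For compound 3 the expected value is 80 ug/mL, with an estimated range from 30 ug/mL to 130 ug/mL.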

Compound 3, solubility: 12.5 ug/mL
For compound 3 the middle estimate is 6.4-fold (0.81 log units) above the measured one; the measured number lies below the stated range.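

In this assay, the place on the amide-type nitrogen now shows a readable change: 4-(hydroxymethyl)-1,3-thiazol-2-yl in place of pyridin-3-yl gives an at least 8.0-fold lower number from compound 2 to compound 3 (0.90 log units; beyond the scatter). Within the 1,3-thiazol-2-yl pair, hydroxy in place of dimethylamino on a saturated chain carbon bound to an aromatic carbon gives an at least 8.0-fold lower number from compound 1 to compound 3 (0.90 log units; beyond the scatter), so the group on that chain carbon also separates two compounds that the earlier pair could not separate. Both steps are floors and not full sizes, because compounds 1 and 2 each sit at a limit and not at a number: the limit of > 100 ug/mL in this assay, at which 2 of the 3 values shown sit.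

The compounds shown do not tell whether the step from compound 2 goes with the 1,3-thiazol-2-yl ring itself or with the hydroxymethyl group on it, and a 4-methyl-1,3-thiazol-2-yl group on the amide-type nitrogen would divide those two readings. Going by these compounds, it also remains open how a carboxylic acid or a primary amine on the same saturated chain carbon would stand against the hydroxy of compound 3 and the dimethylamino of compound 1.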